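The compounds below may be only part of what the source reports. "The series", "measured", "known", "first", "only" and "open" are said of these compounds alone.

Measured compounds:
compound 1, `O=C(CSc1nnc(-c2ccncc2)o1)N/N=C/c1cccc(F)c1`, in an ADME assay on NIH3T3 cells (Mus musculus) for cytotoxicity, read by MTT assay, with a stated time of 24 h (a lower number here means a stronger inhibitor, a higher number a weaker inhibitor), compound 1 gives 205000 nM
compound 2, `O=C(CSc1nnc(-c2ccncc2)o1)N/N=C/c1ccccc1F`, in this assay compound 2 gives 142000 nM

Going by the values given here, compound 2 carries the lowest of the two numbers in this assay, and its only neighbour is compound 1, with a 1.4-fold lower number from compound 1 to compound 2 (0.16 log units; within the scatter). The two compounds therefore sit together within the scatter, and nothing in the numbers sets one apart from the other.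

Compound 3, `O=C(CSc1nnc(-c2ccncc2)o1)N/N=C/c1ccccc1[N+](=O)[O-]`, shares the core of compound 2 and differs from it in one place: nitro in place of fluoro on an aromatic carbon. Among the compounds with values here, the only measured step, a 1.4-fold lower number from compound 1 to compound 2 (0.16 log units; within the scatter), moves a fluoro from one position of the phenyl ring to another and does not exchange the group itself, so it says little about what a nitro in place of fluoro will do. Within the data shown here, no step in these data bears directly on the change from compound 2 to compound 3. On that basis a step of no size beyond the scatter is expected in this assay, as a 1.1-fold lower number from compound 2 to compound 3 (0.04 log units; within the scatter). Compound 3 is accordingly estimated at 130000 nM, with a range from 50000 nM to 350000 nM.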

Compound 3, half-maximal inhibitory concentration: 214000 nM
Beside the measured number, compound 3's estimate is 1.6-fold (0.22 log units) below it, within the range that was stated.
By their numbers in this assay, from the lowest: compounds 2, 1 and 3 (each within the scatter of the next).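

In this assay, going by these compounds alone, the step of a 1.5-fold higher number from compound 2 to compound 3 (0.18 log units; within the scatter) is the only one here that exchanges the group itself on this aromatic carbon rather than moving a fluoro around the phenyl ring, and it leaves the number within the scatter even though nitro is a larger group than fluoro. The comparison with the other fluoro compound reads the same way, with a 1.0-fold higher number from compound 1 to compound 3 (0.02 log units; within the scatter) as its step, so the 2-fluorophenyl, 3-fluorophenyl and 2-nitrophenyl groups all stand within the scatter of one another on the shared core, and none of the three compounds is set apart by its number. Nothing measured here speaks to why the exchange of fluoro for nitro leaves the number where it is.

Whether any group at this place can move the number beyond the scatter remains open, since an amine, a carboxylic acid or a longer chain such as a butoxy group on the same aromatic carbon is not among the compounds shown. Also open, from the compounds shown here alone, is whether changes elsewhere on the shared core, such as on the carbon with a double bond to nitrogen, would do more than these exchanges on the phenyl ring.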